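Working notes: from compound 2 to compound 3

The compounds below may be only part of what the source reports. "The series", "measured", "known", "first", "only" and "open" are said of these compounds alone.

In a functional assay on HT-29 cells (Homo sapiens) for inhibition, read by CCK-8 assay, with a stated time of 24 h (a higher number here means a weaker inhibitor, a lower number a stronger inhibitor), compound 1 (`Cc1cccc(-n2cc(-c3ccc(/C=C4\C(=O)Nc5ccccc54)cc3)nn2)c1`) gives 3940 nM. Within the data shown here, compound 2 (`O=C1Nc2ccccc2/C1=C/c1ccc(-c2cn(-c3ccc(F)cc3)nn2)cc1`) gives 17700 nM, the higher of the two numbers so far, which makes it the weaker inhibitor of this pair.

Compound 3 (`O=C1Nc2ccccc2/C1=C/c1ccc(-c2cn(-c3ccccc3Cl)nn2)cc1`) has not yet been measured. It carries 2-chlorophenyl in place of 4-fluorophenyl on an aromatic nitrogen.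

Among the measured compounds shown here, only one measured step bears on this change: a 4.5-fold higher number from compound 1 to compound 2 (0.65 log units; beyond the scatter). That modest step, beyond the scatter, came with 4-fluorophenyl in place of 3-methylphenyl on an aromatic nitrogen, so the group at this place can shift the number. For the measured compounds named here, no compound with 2-chlorophenyl has been measured, and a single step cannot fix the direction. With compound 2 at the top of the two numbers, a move back toward compound 1 is the more likely outcome, though not a sure one, and its size is expected to stay within that of the measured step.

The estimated step is a 2.2-fold lower number from compound 2 to compound 3 (0.34 log units; beyond the scatter), modest and toward a lower number. For compound 3 the estimated value is 8000 nM, with an expected range of 2500 nM to 25000 nM.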

Compound 3, half-maximal inhibitory concentration: > 20000 nM
Compound 3: a limit, no number; the forecaster's own chance of this, stated with the estimate: 5%; middle value at least 2.5-fold (0.39 log units) away from the limit.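

The reading for compound 3 in this assay is a limit of the assay and not a number: the limit of > 20000 nM in this assay, at which 1 of the 3 values shown sits.

Read as a floor, the change from 4-fluorophenyl to 2-chlorophenyl gives an at least 1.1-fold higher number from compound 2 to compound 3 (0.05 log units; that floor lies within the scatter), so the data do not separate these two groups at this position. The change from 3-methylphenyl to 2-chlorophenyl gives an at least 5.0-fold higher number from compound 1 to compound 3 (0.70 log units; beyond the scatter), and with the earlier step of a 4.5-fold higher number from compound 1 to compound 2 (0.65 log units; beyond the scatter), both halogen-bearing phenyl groups now read as weaker than 3-methylphenyl, leaving compound 1 the strongest inhibitor of the three.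

From the compounds shown here alone, it remains open whether compound 3 is truly a weaker inhibitor than compound 2, and whether any difference between them follows the identity of the halogen or where it sits on the phenyl ring, since both change together in this step. Also open, going by these compounds, is how this assay would read with an unsubstituted phenyl, a 2-methylphenyl or a group carrying an amine on the same aromatic nitrogen.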